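Working notes: cytotoxicity of compound 4, an estimate

This account rests on a few compounds, and the source may have more. Where it says the series, first, only, none or still open, it means among the compounds named here.

Measured so far in an ADME assay on L6 cells (Rattus norvegicus) for cytotoxicity, read by resazurin assay, with a stated time of 72 h; a higher number here means that more compound is needed for the effect, a lower number that less compound is needed:
- compound 1 `CCOC(=O)C1=C(O)/C(=C\c2cc(C)n(-c3ccc(F)cc3)c2C)N=C1C` gives 140000 nM
- compound 2 `CCOC(=O)C1=C(C)N/C(=C/c2cc(C)n(-c3cccc(OC)c3)c2C)C1=O` gives 56000 nM
- compound 3 `CCOC(=O)C1=C(C)N/C(=C/c2cc(C)n(-c3ccc(SC(F)(F)F)cc3)c2C)C1=O` gives 140000 nM

Compound 2 stands at the lowest of the three numbers. Compound 1 and compound 3 each sit at a higher number than compound 2, and both gaps lie beyond the usual scatter of this assay . Compound 1 and compound 3 themselves give the same number. Going by the values given here, no pair of measured compounds differs in only one place, so no single structural step has yet been measured here.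

Compound 4 `CCOC(=O)C1=C(C)N/C(=C/c2cc(C)n(Cc3ccccc3)c2C)C1=O` is the next candidate. It differs from compound 2 in one place: benzyl in place of 3-methoxyphenyl on an aromatic nitrogen. Nothing in the measured set tests this kind of exchange, so any expectation rests only on where compound 2 stands relative to compound 1 and compound 3, which both lie higher. The step is expected to be small, either none beyond the scatter or a modest rise toward the numbers of compound 1 and compound 3. On that basis the number for compound 4 in this assay is estimated at 80000 nM, with a range from 35000 nM to 200000 nM. The expected step of a 1.4-fold higher number from compound 2 to compound 4 (0.15 log units; within the scatter) is accordingly a slight upward one, of a size that could still fall within the scatter.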

Compound 4, half-maximal effective concentration: 50000 nM
The estimate for compound 4 lay 1.6-fold (0.20 log units) above the measured number, within the range that was stated.
By their numbers in this assay, from the lowest: compounds 4 and 2 (each within the scatter of the next); then compounds 1 and 3 (each within the scatter of the next).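

Going by these compounds alone, for the group on the aromatic nitrogen, the first measured one-place exchange in this assay is benzyl in place of 3-methoxyphenyl, and it gives a 1.1-fold lower number from compound 2 to compound 4 (0.05 log units; within the scatter). The entering benzyl carries no hydrogen-bond acceptor and the leaving 3-methoxyphenyl carries one, yet this difference in the group, together with the change from one to the other, produces no step beyond the scatter in this single pair, so the exchange can be made here without a measurable consequence for the read-out. No measurement at hand bears on why the two groups read alike.

Open, as far as these compounds go, is whether this holds for groups of another kind on the same nitrogen, such as a longer chain like phenethyl, a chain ending in an amine, or a benzyl carrying a carboxylic acid. A single pair also leaves open whether benzyl and 3-methoxyphenyl would read alike with other substituents elsewhere on the shared core, such as a different ester in place of the ethyl ester.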